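Cyclopentyl to Benzyl on the Imidazole-Linked Chain

The compounds below may be only part of what the source reports. "The series", "measured", "known", "first", "only" and "open" are said of these compounds alone.

Compound 1 `O=C(O)c1ccccc1-c1ccc(CCc2ncc(CC3CCCC3)[nH]2)cc1` carries a cyclopentyl group on the saturated chain attached to its core. In an in vitro functional assay on cells for agonist activity at Bombesin receptor subtype-3 (Homo sapiens), read by luminescence and calcium flux (on this read-out lower numbers stand for an effect already at smaller amounts and higher numbers for an effect only at larger amounts of compound), compound 1 gives 133 nM. Among the compounds with values here, this is the lower of the two numbers measured so far. The other measured compound, compound 2 `CCCCc1cnc(C(Cc2ccc(-c3ccccc3C(=O)O)cc2)C(C)C)[nH]1`, differs from compound 1 at several places at once, and in this assay compound 2 gives 4620 nM, a gap that lies beyond the scatter of repeated measurements. Since the two differ in more than one place, those two values alone say nothing about any single change.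

Compound 3 `O=C(O)c1ccccc1-c1ccc(CCc2ncc(CCc3ccccc3)[nH]2)cc1` has not yet been measured. It differs from compound 1 in one place: benzyl in place of cyclopentyl on a saturated chain carbon bound to an aromatic carbon. Within the data shown here, nothing measured so far tracks a change of this kind on this chain, so the direction is open. The account expects that the step from compound 1 to compound 3 in this assay stays close to the scatter, a 1.5-fold higher number from compound 1 to compound 3 (0.18 log units; within the scatter). For compound 3 in this assay the estimate is 200 nM, within a range from 40 nM to 1000 nM.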

Compound 3, half-maximal effective concentration: 1320 nM
Beside the measured number, compound 3's estimate is 6.6-fold (0.82 log units) below it; measured number above the stated range.
By their numbers in this assay, from the lowest: compound 1; then compound 3; then compound 2.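

Within the data shown here, with benzyl in place of cyclopentyl on a saturated chain carbon bound to an aromatic carbon, this assay gives the first reading of a single change at this position, a 9.9-fold higher number from compound 1 to compound 3 (1.00 log units; beyond the scatter), which shows that the number here depends on the group at the end of this chain. The step comes from a change in which a five-membered non-aromatic ring of carbon only gives way to a six-membered aromatic ring of carbon only, while the group grows from 5 to 7 heavy atoms and neither group has any hydrogen-bond donors, hydrogen-bond acceptors or net charge. No evidence is available on what lies behind this step.

Ring type and group size change together in this one step, so the compounds shown do not separate the two, and cyclohexylmethyl on the chain would be a direct way to tell them apart. On these data alone, it also remains open how a smaller cyclobutyl ring, a plain butyl chain or a benzyl group carrying an amine would read at this position on the core of compound 1.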